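Half-life notes: phenyl methyl position at the ring carbon

The source may report more compounds than this note shows. Statements on the series, on what has been measured and on what is new or still open speak of the compounds shown alone.

Measured in an in vivo ADME assay on the whole organism for metabolic stability, with Rattus norvegicus as the target, using cassette dosing; on this read-out lower numbers stand for a shorter-lived compound and higher numbers for a longer-lived compound:
compound 1 `CC[C@@]1(O)C[C@H](C(=O)Nc2ccc(-n3cccc(C)c3=O)cc2F)N(C(=O)Nc2ccc(Cl)cc2)C1` gives 5.2 h;
compound 2 `CC[C@@]1(O)C[C@H](C(=O)Nc2ccc(-n3ccccc3=O)cc2F)N(C(=O)Nc2ccc(Cl)cc2)C1` gives 2.4 h;
compound 3 `Cc1ccc([C@@]2(O)C[C@H](C(=O)Nc3ccc(-n4ccccc4=O)cn3)N(C(=O)Nc3ccc(Cl)cc3)C2)cc1` gives 1.8 h.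

Compound 3 carries the lowest of the three numbers, though the gap to compound 2 lies within the scatter; only the gap to compound 1 lies beyond it. Compound 4 `Cc1ccccc1[C@@]1(O)C[C@H](C(=O)Nc2ccc(-n3ccccc3=O)cn2)N(C(=O)Nc2ccc(Cl)cc2)C1` differs from compound 3 by 2-methylphenyl in place of 4-methylphenyl on a saturated ring carbon. For the measured compounds named here, the single measured step, a 2.2-fold lower number from compound 1 to compound 2 (0.34 log units; beyond the scatter), concerns a methyl on a different aromatic ring and was modest. Going by the values given here, no measured pair compares the two methyl positions on the phenyl at the saturated ring carbon, so no step beyond the scatter is expected in this assay. For compound 4 the estimate is 1.8 h, between 0.9 h and 3.6 h. The expected step is no change at the digits printed from compound 3 to compound 4 (within the scatter).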

Compound 4, half-life: 1.3 h
Estimate against measurement, compound 4: 1.4-fold (0.14 log units) above, within the range that was stated.
By their numbers in this assay, from the lowest: compounds 4, 3 and 2 (each within the scatter of the next); then compound 1.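

In this assay, for the compounds shown here, the exchange of 4-methylphenyl for 2-methylphenyl on the saturated ring carbon gives a 1.4-fold lower number from compound 3 to compound 4 (0.14 log units; within the scatter) and so offers the first direct comparison of these two methyl positions. Half-life at this position therefore does not separate the two isomers, both of which stay within the scatter of each other. No available data explain this result.

As far as these compounds go, whether an amine or a carboxylic acid in place of the methyl on this phenyl would shift half-life beyond the scatter remains open.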